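Aryl variation on the ring amide nitrogen of the core

The source may hold more compounds than are shown below. What is called first, only, known or untested is meant among the compounds shown, and "the series" means these compounds.

Measured so far:
compound 1 `CO[C@@H]1CC=C2NN(c3cc(F)cc(Cl)c3)C(=O)C[C@]2(c2ccccc2)O1`: 17400 nM
compound 2 `CO[C@@H]1CC=C2NN(c3cc4ccccc4[nH]3)C(=O)C[C@]2(c2ccccc2)O1`: 9100 nM

In a functional assay on SK-N-SH cells (Homo sapiens) for inhibition, read by sulforhodamine B assay, with a stated time of 48 h (on this read-out higher numbers stand for weaker inhibition and lower numbers for stronger inhibition), compound 2 gives 9100 nM, the lower of the two numbers, while compound 1 gives 17400 nM; the step of a 1.9-fold lower number from compound 1 to compound 2 (0.28 log units; within the scatter) stays within the scatter. Compound 3 `CO[C@@H]1CC=C2NN(c3cncnc3)C(=O)C[C@]2(c2ccccc2)O1` is not yet measured. It differs from compound 2 by pyrimidin-5-yl in place of 1H-indol-2-yl on an amide-type nitrogen in a ring. Going by the values given here, the only measured step exchanges one aryl group on the same nitrogen and moves the number little; no measured step covers a pyrimidinyl group there. For compound 3 a step of a 1.6-fold higher number from compound 2 to compound 3 (0.22 log units; within the scatter) is expected, toward a somewhat higher number or none beyond the scatter. Compound 3 is estimated at 15000 nM, between 5000 nM and 50000 nM.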

Compound 3, half-maximal inhibitory concentration: 8200 nM
Estimate against measurement, compound 3: 1.8-fold (0.26 log units) above; the range from low to high includes it.
By their numbers in this assay, from the lowest: compounds 3, 2 and 1 (each within the scatter of the next, the first and the last beyond it).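

In this assay, replacing 1H-indol-2-yl, which has a hydrogen-bond donor, with pyrimidin-5-yl, which has none and carries two acceptors, gives a 1.1-fold lower number from compound 2 to compound 3 (0.05 log units; within the scatter). Against 3-chloro-5-fluorophenyl, the same group gives a 2.1-fold lower number from compound 1 to compound 3 (0.33 log units; beyond the scatter), the only step beyond the scatter among these three compounds, and a modest one. No evidence bearing on either step is available.

Going by these compounds, all three groups on this nitrogen are aromatic rings, so the effect of an aminoalkyl chain or a carboxylic acid there remains open. Also open, on these data alone, is any change to the phenyl group on the core, which is the same in all three compounds.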